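Changing the Triazole Substituent of Compound 2

The compounds below may be only part of what the source reports. "The series", "measured", "known", "first", "only" and "open" are said of these compounds alone.

Compound 1 `CCOC(=O)C1=Cc2ccccc2OC1(OCc1cc(-c2ccc(C)cc2)no1)C(F)(F)F`: > 150000 nM in a functional assay on MCF7 cells (Homo sapiens) for inhibition, read by MTT assay, with a stated time of 24 h (on this read-out higher numbers stand for weaker inhibition and lower numbers for stronger inhibition), a limit of the assay rather than a number.
Compound 2 `CCOC(=O)C1=Cc2ccccc2OC1(OCc1cn(CC(=O)NC2CCCCC2)nn1)C(F)(F)F`: 12100 nM in this assay.
Compound 3 `CCOC(=O)C1=Cc2ccccc2OC1(OCc1cc(-c2ccc(Br)cc2)no1)C(F)(F)F`: > 150000 nM in this assay, again a limit of the assay rather than a number.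

Among the compounds with values here, compound 2 stands alone as the only measured number in this set; the two other values sit at a limit, as the record shows: the limit of > 150000 nM in this assay, at which 2 of the 3 values shown sit. The step that the two limits leave unreadable from compound 1 to compound 3 is therefore unreadable and offers no guidance.

Compound 4 `CCOC(=O)C1=Cc2ccccc2OC1(OCc1cn(-c2cccc(C(F)(F)F)c2)nn1)C(F)(F)F` has not yet been measured. It differs from compound 2 by 3-(trifluoromethyl)phenyl in place of (cyclohexylcarbamoyl)methyl on an aromatic nitrogen. Within the data shown here, no measured step bears on this change, since the one pair that differs in a single place is hidden behind the limit. The account can only note that compound 2 gives 12100 nM. Compound 1 and compound 3, which share the same core, each sit at a limit of the assay. The expected step of a 1.7-fold higher number from compound 2 to compound 4 (0.22 log units; within the scatter) is thus set near zero, with a wide range and a real chance that compound 4 returns only a limit. For compound 4 the estimate is 20000 nM, expected between 5000 nM and 100000 nM.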

Compound 4, half-maximal inhibitory concentration: > 150000 nM
Compound 4: only a limit was reported; the forecaster's own chance of this, stated with the estimate: 35%; at least 7.5-fold (0.87 log units) between middle value and limit.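

Within the data shown here, the substituent on this aromatic nitrogen matters in this assay: 3-(trifluoromethyl)phenyl in place of (cyclohexylcarbamoyl)methyl gives an at least 12-fold higher number from compound 2 to compound 4 (1.09 log units; beyond the scatter), the only readable step in the set. Compound 4 gives > 150000 nM, a limit of the assay and not a number, so the step has a lower bound but no known full size. Compound 2 remains the only compound with a measured number, and the limit now holds most of the set: the limit of > 150000 nM in this assay, at which 3 of the 4 values shown sit.

The change replaces the non-aromatic ring, the carbonyl and the amide hydrogen in a single move, so the compounds shown cannot say which of these parts goes with the measured value of compound 2. Also open, as far as these compounds go, is how a plain cyclohexyl group or an open-chain amide such as (butylcarbamoyl)methyl would read on this nitrogen.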